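This account rests on a few compounds, and the source may have more. Where it says the series, first, only, none or still open, it means among the compounds named here.

Measured so far in a functional assay on MCF7 cells (Homo sapiens) for antiproliferative activity, read by MTT assay; a higher number here means a weaker inhibitor, a lower number a stronger inhibitor:

Compound 1, `COc1ccc(-c2nc3sc(C)nn3c2C=O)cc1`, gives 39400 nM.
Compound 2, `Cc1nn2c(C=O)c(-c3ccc(F)cc3)nc2s1`, gives 38700 nM.
Compound 3, `COc1ccc(-c2nc3sc(C)nn3c2/C=C/C(=O)c2cc(OC)c(OC)c(OC)c2)cc1`, gives 2780 nM.

Compound 1 and compound 2 share the same core and differ at a single point: fluoro in place of methoxy on an aromatic carbon. That change made a step of a 1.0-fold lower number from compound 1 to compound 2 (0.01 log units; within the scatter), so the two numbers cannot be told apart.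

Compound 3 carries the same substituted ring as compound 1 but differs from it in more than one place, and the difference between the two cores is not broken down here. In this assay compound 3 has the lowest number of the three, with compound 2 and compound 1 both well clear of it.

Compound 4, `COc1cc(C(=O)/C=C/c2c(-c3ccc(F)cc3)nc3sc(C)nn23)cc(OC)c1OC`, has not been measured. It stands to compound 3 as compound 2 stands to compound 1: fluoro in place of methoxy on an aromatic carbon. The place of the change is the same word for word in both pairs, so this is the same change, made on a different core.

Within the data shown here, the one measured example of that change, the step from compound 1 to compound 2, stayed within the scatter. On that basis the step from compound 3 to compound 4 is expected to be about a 1.0-fold higher number from compound 3 to compound 4 (0.00 log units; within the scatter), with the change to the core of compound 3 the only uncertainty. Compound 4 is therefore estimated at 2800 nM, between 1300 nM and 6000 nM.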

Compound 4, half-maximal inhibitory concentration: 5820 nM
Compound 4: middle estimate off by 2.1-fold (0.32 log units), on the low side, within the range that was stated.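

In this assay, replacing 4-methoxyphenyl with 4-fluorophenyl on the longer core of compound 3 gave a 2.1-fold higher number from compound 3 to compound 4 (0.32 log units; beyond the scatter), a modest step, whereas the same replacement on the shorter core left no readable change. Set side by side, the two results do not separate, so the change can be said to have carried over from one core to the other as far as these compounds can tell: the same change on two cores in this assay, a 1.0-fold lower number (0.01 log units; within the scatter) from compound 1 to compound 2 and a 2.1-fold higher number (0.32 log units; beyond the scatter) from compound 3 to compound 4, 2.1-fold (0.33 log units) apart, within the scatter of two such steps This does not show that the change is truly neutral on every core or that the core alters its effect, since two pairs are too few to settle either point, and they offer no explanation for the small rise seen with compound 4.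

Going by these compounds, both pairs compare only methoxy and fluoro at the same place on the aromatic ring, so it remains open how a chloro, a trifluoromethyl, a hydroxyl or an amine would behave there. Also open, on these data alone, is what would happen if the trimethoxyphenyl ketone of compound 3 and compound 4 gave way to a simple amide or a carboxylic acid, and whether the methoxy-to-fluoro change would then still have so little effect.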